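The source may report more compounds than this note shows. Statements on the series, on what has been measured and on what is new or still open speak of the compounds shown alone.

Measured so far in an assay on isolated protein for inhibition of adenosine deaminase (Bos taurus), with a stated time of 5 min; on this read-out higher numbers stand for weaker inhibition and lower numbers for stronger inhibition:
compound 1 `C[C@H](O)[C@@H](CCc1cccc(F)c1)n1cnc2c(N)ncnc21` gives 1.6 nM
compound 2 `C[C@H](O)[C@@H](CCc1cccc(Br)c1)n1cnc2c(N)ncnc21` gives 0.6 nM

Compound 2 holds the lowest of the two numbers in this assay; the only other measured point, compound 1, sits at a 2.7-fold lower number from compound 1 to compound 2 (0.43 log units; beyond the scatter). Compound 3 `COC(=O)c1cccc(CC[C@H]([C@H](C)O)n2cnc3c(N)ncnc32)c1` differs from compound 2 by methoxycarbonyl in place of bromo on an aromatic carbon. Among the measured compounds shown here, no measured step exchanges a halogen for an ester; the one step in hand, a 2.7-fold lower number from compound 1 to compound 2 (0.43 log units; beyond the scatter), swaps halogens only and gives no direct guide. A modest move is therefore expected, more likely toward a higher number, as a 2.5-fold higher number from compound 2 to compound 3 (0.40 log units; beyond the scatter). For compound 3 the estimate is 1.5 nM, range 0.4 nM to 6 nM.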

Compound 3, inhibition constant: 2.2 nM
Compound 3: middle estimate off by 1.5-fold (0.17 log units), on the low side, and the stated range covers the measured number.
By their numbers in this assay, from the lowest: compound 2; then compounds 1 and 3 (each within the scatter of the next).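

At this aromatic carbon, meta to a large group, the series tolerates more than a halogen: in this assay, methoxycarbonyl in place of bromo gives a 3.7-fold higher number from compound 2 to compound 3 (0.56 log units; beyond the scatter). Methoxycarbonyl in place of fluoro gives a 1.4-fold higher number from compound 1 to compound 3 (0.14 log units; within the scatter), so compound 2 alone stands apart among the three. Nothing available explains either step.

From the compounds shown here alone, how a carboxylic acid or an amine at this carbon would compare with methoxycarbonyl remains open. Also open, going by these compounds, is whether the advantage of bromo holds elsewhere on the ring.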